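A few compounds are considered here, and "the series" means these few. Any claim that something is new, unique, unknown or untested is made for them only; others in the source may bear on it.

The measured compounds:
compound 1, `CCC[C@@H](OC(C)=O)C1=C(Br)C(=C(Br)Br)OC1=O`, with 0.3 ug/mL;
compound 2, `CCC[C@@H](OC(C)=O)C1=C(Br)[C@@](C)(OC)OC1=O`, with 5.4 ug/mL.

In a functional assay on KB cells (Homo sapiens) for cytotoxicity (a lower number here means that less compound is needed, a higher number that more compound is needed for the effect), compound 2 stands at the higher of the two numbers. Compound 1, with its 0.3 ug/mL, sits well below compound 2, and that gap lies beyond the usual scatter. The two compounds differ in more than one place, so nothing more can be said of what separates them.

Compound 3, `CCC[C@@H](OC(C)=O)C1=C(Br)[C@@](CI)(OC)OC1=O`, has not yet been measured. It differs from compound 2 in one place: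

iodo in place of hydrogen on a saturated chain carbon bound to a saturated ring carbon

For the measured compounds named here, no pair of measured compounds shows this change, so its effect is unknown here. The expectation is a small step from compound 2 to compound 3, a 1.4-fold lower number from compound 2 to compound 3 (0.13 log units; within the scatter), in either direction and not clearly beyond the scatter. Compound 3 is therefore expected to give about 4 ug/mL, with a range from 1.5 ug/mL to 12 ug/mL.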

Compound 3, concentration for half-maximal effect: 2.4 ug/mL
For compound 3 the middle estimate is 1.7-fold (0.22 log units) above the measured one, and the stated range covers the measured number.
By their numbers in this assay, from the lowest: compound 1; then compound 3; then compound 2.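

In this assay, iodo in place of hydrogen on a saturated chain carbon bound to a saturated ring carbon gives a 2.3-fold lower number from compound 2 to compound 3 (0.35 log units; beyond the scatter), the only single-place change among these compounds. For the compounds shown here, this is the first sign that the number responds to a change at this position, and that the methyl to iodomethyl change moves it towards less compound being needed, modestly but beyond the scatter. Nothing available here accounts for the step.

On these data alone, what a chloromethyl or bromomethyl group would give at this place stays open, and so does whether the step is specific to iodine or would appear with any halogen. Also open, as far as these compounds go, is whether an aminomethyl group or a longer chain would move the number in the same direction, or whether the step would carry over to other members.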